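Removing the selenium-bearing chain from compound 2

This account rests on a few compounds, and the source may have more. Where it says the series, first, only, none or still open, it means among the compounds named here.

For the measured compounds named here, in a functional assay on A549 cells (Homo sapiens) for inhibition, read by MTT assay, with a stated time of 48 h (a lower number here means a stronger inhibitor, a higher number a weaker inhibitor), compound 2 `COc1ccc(N(C)c2nc(C)nc3ccccc23)cc1OCCCC[Se]C#N` gives 1200 nM, the higher of the two numbers so far, while compound 1 `COc1ccc(N(C)c2nc(C)nc3ccccc23)cc1C(=O)NCC[Se]C#N` gives 187 nM. Compound 3 `COc1ccc(N(C)c2nc(C)nc3ccccc23)cc1` carries no such chain: a hydrogen atom in place of a group of 8 heavy atoms (5 carbon, 1 nitrogen, 1 oxygen, 1 selenium; no ring), on an aromatic carbon, ortho to a methoxy group and meta to a large group. Going by the values given here, only one measured step bears on this change: a 6.4-fold higher number from compound 1 to compound 2 (0.81 log units; beyond the scatter), a modest step in which one chain replaces another. Among the compounds with values here, no measured compound lacks the chain, so the direction remains a judgement. Removing the whole group is a larger structural change than that swap, so a larger step towards a lower number is expected in this assay, with wide uncertainty. The expected step runs a 60-fold lower number from compound 2 to compound 3 (1.78 log units; beyond the scatter). For compound 3 the estimated value is 20 nM, with an expected range of 2 nM to 200 nM.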

Compound 3, half-maximal inhibitory concentration: 3 nM
The estimate for compound 3 lay 6.7-fold (0.82 log units) above the measured number, and the stated range covers the measured number.
By their numbers in this assay, from the lowest: compound 3; then compound 1; then compound 2.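

In this assay, hydrogen on this aromatic carbon gives a 400-fold lower number from compound 2 to compound 3 (2.60 log units; beyond the scatter) and a 62-fold lower number from compound 1 to compound 3 (1.79 log units; beyond the scatter), so neither selenium-bearing chain is needed for the low number in this series. The earlier compounds shown here compared only one chain with another; now both chains, ortho to the methoxy group, stand on the weaker side of hydrogen, and the shared core alone gives the lowest number of the three. No measurement at hand bears on the reason for this drop.

From the compounds shown here alone, whether the selenium atom, the nitrile or the chain as a whole goes with the higher numbers remains open, and a plain butoxy chain ending in carbon would help separate these. Also open, going by these compounds, is whether a small group at this place, such as a hydroxyl or an amine, stays close to compound 3.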